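This account rests on a few compounds, and the source may have more. Where it says the series, first, only, none or still open, it means among the compounds named here.

Measured compounds in an in vitro assay on BTI-TN-5B1-4 cells for inhibition of Amine oxidase [flavin-containing] B (Homo sapiens), tested at 100 uM; on this read-out higher numbers stand for more inhibition at the one concentration tested (going by the name of the read-out) and lower numbers for less inhibition:
- compound 1 `S=c1cc(-c2ccccc2)oc2ccccc12` gives 40%
- compound 2 `Fc1ccc(-c2cc(=S)c3ccccc3o2)cc1` gives "not active" (no number reported)
- compound 3 `Cc1ccc(-c2cc(=O)c3ccc(C)cc3o2)cc1` gives 40%

Compound 1 stands level with compound 3 in this assay at the digits given; the two readings lie within the scatter of each other, so no order between them can be stated. Compound 2 is reported in this assay without a number. Within the data shown here, compound 3 differs from compound 1 in more than one place, so its reading does not isolate any single change; no pair of measured compounds differing in one place is available.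

Compound 4 `COc1ccc2c(=S)cc(-c3ccccc3)oc2c1` is not yet measured in this assay. It differs from compound 1 by methoxy in place of hydrogen on an aromatic carbon. Among the measured compounds shown here, no measured pair shows this change alone, so the expectation rests only on the level held by compound 1 at 40% and on compound 3 reaching a level within the scatter of it with different substitution. The step from compound 1 to compound 4 is expected to be a number 2 percentage points lower from compound 1 to compound 4 (within the scatter), none beyond the scatter. Compound 4 is thus expected to give 38%, with a range from 12% to 62%; a report without a number, as for compound 2, remains possible.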

Compound 4, a percentage reported as inhibition, at one concentration (the size of the read-out at that concentration, not a potency): 40%
Compound 4: the middle estimate sits 2 percentage points below what was measured; measured number inside the range.
By their numbers in this assay, from the lowest: compounds 1, 3 and 4 (each within the scatter of the next).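

In this assay, among these compounds, methoxy in place of hydrogen on an aromatic carbon gives no change at the digits printed from compound 1 to compound 4 (within the scatter), the first reading that isolates a single change. At this place, meta to a fused ring and para to a fused ring, the added methoxy therefore leaves the reading at the one tested concentration unmoved, though a read-out of this kind is not a potency and cannot show whether potency shifts. No measurement offered here bears on why the reading stays level.

Going by these compounds, whether an amine, a carboxylic acid or a longer alkoxy chain on the same aromatic carbon would also leave the reading level remains open. Also open, on these data alone, is whether methoxy would give the same result on the other aromatic carbons of the core.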